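Swapping the chain end: from basic ring to amide

The source may hold more compounds than are shown below. What is called first, only, known or untested is meant among the compounds shown, and "the series" means these compounds.

Compound 2 `Cc1ccccc1C(=O)Nc1ccc(C(=O)N2CCCC(NCCCN3CCCCC3)c3cc(Cl)ccc32)c(C)c1` carries a 3-(piperidin-1-yl)propyl chain on its amine nitrogen. In a physicochemical assay for solubility, measured as thermodynamic solubility, with a stated time of 24 h (a higher number here means a more soluble compound, a lower number a less soluble compound), compound 2 gives 2.3 ug/mL. Its closest measured neighbour, compound 1 `Cc1ccccc1C(=O)Nc1ccc(C(=O)N2CCCC(NCCCc3ccncc3)c3cc(Cl)ccc32)c(C)c1`, gives 2.3 ug/mL in this assay, and the step of no change at the digits printed from compound 1 to compound 2 (within the scatter) shows that exchanging the pyridin-4-yl for piperidin-1-yl left the number unchanged. Compound 3 `Cc1ccccc1C(=O)Nc1ccc(C(=O)N2CCCC(NCCC(=O)N3CCOCC3)c3cc(Cl)ccc32)c(C)c1` has not yet been measured. It differs from compound 2 by (morpholin-4-yl)carbonyl in place of (piperidin-1-yl)methyl on a saturated chain carbon, two bonds along the chain from an amine nitrogen. Among the compounds with values here, no measured step covers this particular exchange: the one step in hand swapped one ring for another at the same chain end, and it moved nothing beyond the scatter. On that basis the step of a 1.3-fold lower number from compound 2 to compound 3 (0.11 log units; within the scatter) is expected to stay small, with the direction uncertain. In this assay compound 3 is therefore estimated at 1.8 ug/mL, within a range from 0.5 ug/mL to 6 ug/mL.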

Compound 3, solubility: 2.3 ug/mL
For compound 3 the middle estimate is 1.3-fold (0.11 log units) below the measured one; low and high end bracket the measured number.
By their numbers in this assay, from the lowest: compounds 1, 2 and 3 (each within the scatter of the next).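

The exchange at this position now goes beyond one ring for another: a carbonyl enters at the place two bonds along the chain from an amine nitrogen, and the ring gains a second hetero atom, yet the read-out in this assay shows no change at the digits printed from compound 2 to compound 3 (within the scatter) as the step. Set against the pyridine-bearing chain, the same end gives the same picture (no change at the digits printed from compound 1 to compound 3 (within the scatter)), so all three chain ends shown stand level within the scatter. No supporting data bear on why this number holds across these exchanges.

The compounds shown do not separate the carbonyl from the ring change, which (piperidin-1-yl)carbonyl or (morpholin-4-yl)methyl at this place would do. As far as these compounds go, how a carboxylic acid at the chain end, or a longer chain, would read also stays open.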